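Swapping dimethylamino for methylsulfanyl in compound 1

The source may hold more compounds than are shown below. What is called first, only, known or untested is meant among the compounds shown, and "the series" means these compounds.

Measured so far in a functional assay on DU-145 cells (Homo sapiens) for inhibition, read by trypan blue exclusion, with a stated time of 96 h (on this read-out lower numbers stand for stronger inhibition of growth and higher numbers for weaker inhibition of growth), these compounds give:
- compound 1 (`CN(C)c1ccc(/C=C(/SCc2ccc(Cl)cc2)C(=O)c2ccc(C(=O)O)cc2)cc1`) gives 1000 nM as its value
- compound 2 (`O=C(/C(=C\c1ccc(-c2ccccc2)s1)SCc1ccc(F)cc1)c1ccc(Br)cc1`) gives > 100000 nM which is a limit of the assay, not a number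
- compound 3 (`CN(C)c1ccc(/C=C(/SCc2ccc(Br)cc2)C(=O)c2ccc(C(=O)O)cc2)cc1`) gives 50000 nM as its value

Compound 1 holds the lower of the two exact numbers, and compound 3 is its nearest neighbour. Compound 4 (`CSc1ccc(/C=C(/SCc2ccc(Cl)cc2)C(=O)c2ccc(C(=O)O)cc2)cc1`) has methylsulfanyl in place of dimethylamino on an aromatic carbon. Going by the values given here, the only measured step is a different swap, bromo in place of chloro (a 50-fold higher number from compound 1 to compound 3 (1.70 log units; beyond the scatter)), so it bears only indirectly, showing that one small change can move the number far in this set. Compound 1 sits at the low end (1000 nM), so a higher number, beyond the scatter, is expected in this assay (expected: a 5.0-fold higher number from compound 1 to compound 4 (0.70 log units; beyond the scatter)). Compound 4 is estimated at 5000 nM (range 700 nM to 40000 nM).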

Compound 4, concentration for 50% growth inhibition: > 100000 nM
Compound 4: a limit, no number; the forecaster's own chance of this, stated with the estimate: 15%; at least 20-fold (1.30 log units) between middle value and limit.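

In this assay, methylsulfanyl in place of dimethylamino gives an at least 100-fold higher number from compound 1 to compound 4 (2.00 log units; beyond the scatter). Until now only the halogen swap had shown a large move, so this is the first sign that the number in this set also depends heavily on the group at this place on the ring. Compound 4 gives > 100000 nM, which is a limit and not a number, so the full size of the step stays unknown: the limit of > 100000 nM in this assay, at which 2 of the 4 values shown sit.

The compounds shown leave open whether dimethylamino itself is needed here, or whether another amine, such as methylamino, or an ether, such as methoxy, would keep the number close to that of compound 1.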